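The compounds below may be only part of what the source reports. "The series", "measured", "known", "first", "only" and "open" are said of these compounds alone.

Working notes on the urea-bearing series, read for growth inhibition in a functional assay on EC9706 cells (Homo sapiens) for cytotoxicity, read by MTT assay, with a stated time of 72 h; on this read-out higher numbers stand for weaker inhibition and lower numbers for stronger inhibition.

Compound 1 `CCNC(=O)N1CCN(C(=S)SCc2cn(Cc3ccc(Cl)cc3)nn2)CC1` does not reach a number in this assay: its result of > 128000 nM is a limit of the assay. Compound 2 `CC(C)NC(=O)N1CCN(C(=S)SCc2cn(Cc3ccc(Cl)cc3)nn2)CC1` gives 25600 nM in this assay. Within the data shown here, the single change between the two, (methyl in place of hydrogen on a saturated chain carbon bound to an amide-type nitrogen and a saturated chain carbon), produces an at least 5.0-fold lower number from compound 1 to compound 2 (0.69 log units; beyond the scatter); the step can only be given as a lower bound because of the limit of > 128000 nM in this assay, at which 2 of the 3 values shown sit.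

Compound 3 `CCNC(=O)N1CCN(C(=S)SCc2cn(Cc3cc(OC)c(OC)c(OC)c3)nn2)CC1` carries the same change of core relative to compound 1, and the difference between the two cores is not broken down here. In this assay compound 3 also returns only a limit, > 128000 nM. Compound 4 `COc1cc(Cn2cc(CSC(=S)N3CCN(C(=O)NC(C)C)CC3)nn2)cc(OC)c1OC` has not yet been measured; it stands to compound 3 as compound 2 stands to compound 1, the same change being (methyl in place of hydrogen on a saturated chain carbon bound to an amide-type nitrogen and a saturated chain carbon), with the place described in identical words in both pairs.

Among the measured compounds shown here, on the one precedent available, compound 4 is expected to move off the limit by a step of about an at least 3.2-fold lower number from compound 3 to compound 4 (0.50 log units; beyond the scatter), resting on the measured at least 5.0-fold lower number from compound 1 to compound 2 (0.69 log units; beyond the scatter); since that earlier step is itself only a lower bound, the true gain may be larger, and since compound 3 sits at the limit the starting point is uncertain. The estimate for compound 4 in this assay is 40000 nM, with a range from 12000 nM to 128000 nM, and an appreciable chance that only a limit is again reported.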

Compound 4, half-maximal inhibitory concentration: > 128000 nM
Compound 4 was reported as a limit; the forecaster's own chance of this, stated with the estimate: 35%; middle value at least 3.2-fold (0.50 log units) away from the limit.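

Compound 3 and compound 4 both return only a limit in this assay, so no step between them can be read: the limit of > 128000 nM in this assay, at which 3 of the 4 values shown sit.

The compounds shown leave open whether ethyl to isopropyl has any effect on the read-out on the core of compound 3, and so whether the step seen on the core of compound 1 carries over to it.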